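The source may report more compounds than this note shows. Statements on the series, on what has been measured and on what is new or still open speak of the compounds shown alone.

Of the compounds shown here, two have measured values so far. Compound 1 `O=C(Oc1ccccc1)N1CCC(CCn2ccc3ncccc32)CC1` gives 1700 nM in an assay on microsomes from brain for inhibition of Fatty-acid amide hydrolase 1 (Rattus norvegicus), read by HPLC, with a stated time of 60 min; a higher number here means a weaker inhibitor, a lower number a stronger inhibitor. Compound 2 `O=C(Oc1ccccc1)N1CCC(CCn2ccc3cc(F)ccc32)CC1` gives 130 nM in this assay, the lowest of the two numbers; its nearest neighbour, compound 1, sits well above it, beyond the usual scatter.

Compound 3 `O=C(Oc1ccccc1)N1CCC(CCn2ccc3cc(Cl)ccc32)CC1` has not yet been measured. It differs from compound 2 in one place: chloro in place of fluoro on an aromatic carbon. Within the data shown here, no single-change step among the measured compounds shows what such an exchange does here. From the structural change alone, a small step in this assay is expected, either toward a slightly lower number or none beyond the scatter. Compound 3 is therefore expected to give about 100 nM, within a range from 40 nM to 300 nM. This amounts to an expected step of a 1.3-fold lower number from compound 2 to compound 3 (0.11 log units; within the scatter) of modest size.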

Compound 3, half-maximal inhibitory concentration: 410 nM
The estimate for compound 3 lay 4.1-fold (0.61 log units) below the measured number, and the stated range ends below it.
By their numbers in this assay, from the lowest: compound 2; then compound 3; then compound 1.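

In this assay, chloro in place of fluoro on this aromatic carbon gives a 3.2-fold higher number from compound 2 to compound 3 (0.50 log units; beyond the scatter) and so moves the number beyond the scatter. This position therefore distinguishes between two halogens, even though each counts as one heavy atom with no hydrogen-bond donors or acceptors and no net charge. Among these compounds, of the two groups, fluoro goes with the lower number, and this is the only single-change step available. Nothing available here explains the direction of this step.

From the compounds shown here alone, whether bromo would raise the number further remains open, as does what a methoxy group, a nitrile or a plain hydrogen would do on this carbon. It is also unknown whether either halogen would give a similar number on another carbon of this six-membered ring.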